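The compounds below may be only part of what the source reports. "The series", "measured", "known", "first", "only" and "open" are said of these compounds alone.

Working notes on the thiophene-sulfonamide urea series.

Three compounds have been run so far: compound 1 `COc1ccc(Oc2ccc(C(C)C)cc2-c2ccsc2S(=O)(=O)NCCNC(=O)Nc2cc(Cl)cc(Cl)c2)cc1OC`, compound 2 `Cc1ccc(-c2ccsc2S(=O)(=O)NCCNC(=O)Nc2cc(C(F)(F)F)cc(C(F)(F)F)c2)c(Oc2ccc(O)c(O)c2)c1` and compound 3 `CC(C)c1ccc(Oc2ccc(O)c(O)c2)c(-c2ccsc2S(=O)(=O)NCCNC(=O)Nc2cc(Cl)cc(Cl)c2)c1`. In a functional assay on HL-60 cells (Homo sapiens) for inhibition, read by CCK-8 assay, with a stated time of 48 h (a higher number here means a weaker inhibitor, a lower number a stronger inhibitor), compound 1 gives 6500 nM. Compound 2 gives 3700 nM in this assay, and compound 3 gives 6500 nM. All three values sit within the usual scatter of one another, so no order among them is claimed.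

Within the data shown here, the one matched pair measured to date is compound 3 to compound 1, where the change is 3,4-dimethoxyphenyl in place of 3,4-dihydroxyphenyl on an oxygen on an aromatic ring. That step reads no change at the digits printed from compound 3 to compound 1 (within the scatter).

Compound 4 `COc1ccc(Oc2cc(C)ccc2-c2ccsc2S(=O)(=O)NCCNC(=O)Nc2cc(C(F)(F)F)cc(C(F)(F)F)c2)cc1OC` is not yet measured. It differs from compound 2 by 3,4-dimethoxyphenyl in place of 3,4-dihydroxyphenyl on an oxygen on an aromatic ring, the same change as from compound 3 to compound 1, at a place described in identical words. How the core of compound 2 differs from the core of compound 3 is not broken down here.

Resting on the flat step from compound 3 to compound 1, the step from compound 2 to compound 4 in this assay is expected to be no change at the digits printed from compound 2 to compound 4 (within the scatter). Compound 4 is therefore estimated at 3700 nM, with a likely span from 1800 nM to 7500 nM.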

Compound 4, half-maximal inhibitory concentration: 5300 nM
Estimate against measurement, compound 4: 1.4-fold (0.16 log units) below; low and high end bracket the measured number.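

In this assay, the exchange of 3,4-dihydroxyphenyl for 3,4-dimethoxyphenyl can now be read on two cores, and the new step is a 1.4-fold higher number from compound 2 to compound 4 (0.16 log units; within the scatter). Set beside the earlier step, the two agree: the same change on two cores in this assay, no change at the digits printed (within the scatter) from compound 3 to compound 1 and a 1.4-fold higher number (0.16 log units; within the scatter) from compound 2 to compound 4, 1.4-fold (0.16 log units) apart, within the scatter of two such steps

Across these four compounds, then, the change carries from one core to the other as a flat step, and removing the hydrogen-bond donors counted on 3,4-dihydroxyphenyl moves neither reading beyond the scatter. Among these compounds, this does not show that the change is silent on every core, and a small real effect cannot be told from scatter with only two steps in one cell assay.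

Still open, going by these compounds, is how the series reads when a phenyl ring bearing a carboxylic acid or an amine stands on the oxygen in place of either group. Also open, on these data alone, is whether ethoxy or a longer alkoxy chain in place of the methoxy groups of 3,4-dimethoxyphenyl would keep the step flat.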